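The compounds below may be only part of what the source reports. "The series", "measured", "known", "first", "only" and "open" are said of these compounds alone.

Measured so far:
- compound 1, `CC(C)(C)c1ccc(C(=O)/C=C/C(=O)O)cc1`: in a functional assay on HeLa cells (Homo sapiens) for inhibition, read by MTT assay, with a stated time of 72 h (a higher number here means a weaker inhibitor, a lower number a stronger inhibitor), compound 1 gives 5100 nM
- compound 2, `O=C(O)/C=C/C(=O)c1ccc(Br)cc1`: compound 2 gives 18700 nM
- compound 3, `O=C(O)/C=C/C(=O)c1ccc(Cl)cc1`: compound 3 gives 25400 nM

Compound 3 shows the highest number of the three. Its gap to compound 2, a 1.4-fold higher number from compound 2 to compound 3 (0.13 log units; within the scatter), is within the scatter, so the two cannot be ranked; its gap to compound 1, a 5.0-fold higher number from compound 1 to compound 3 (0.70 log units; beyond the scatter), is beyond the scatter.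

Compound 4 is `O=C(O)/C=C/C(=O)c1ccccc1`. The change from compound 3 is hydrogen in place of chloro on an aromatic carbon. Within the data shown here, no measured step removes a group from this position altogether, so the expectation rests on neighbouring steps. The steps of a 3.7-fold higher number from compound 1 to compound 2 (0.56 log units; beyond the scatter) and a 5.0-fold higher number from compound 1 to compound 3 (0.70 log units; beyond the scatter) show the number rising when tert-butyl gives way to a halogen, while a 1.4-fold higher number from compound 2 to compound 3 (0.13 log units; within the scatter) shows that exchanging one halogen for the other stays within the scatter. Going further, to hydrogen, is therefore expected to bring a small rise or no step beyond the scatter in this assay.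

Compound 4 is expected to give about 35000 nM in this assay. The estimate for compound 4 spans 12000 nM to 100000 nM. The expected step is a 1.4-fold higher number from compound 3 to compound 4 (0.14 log units; within the scatter).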

Compound 4, half-maximal inhibitory concentration: 30600 nM
Estimate against measurement, compound 4: 1.1-fold (0.06 log units) above; the range from low to high includes it.
By their numbers in this assay, from the lowest: compound 1; then compounds 2, 3 and 4 (each within the scatter of the next).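

In this assay, taking the halogen off this aromatic carbon altogether gives no step beyond the scatter, whether hydrogen replaces chloro (a 1.2-fold higher number from compound 3 to compound 4 (0.08 log units; within the scatter)) or bromo (a 1.6-fold higher number from compound 2 to compound 4 (0.21 log units; within the scatter)). Compound 2, compound 3 and compound 4 therefore cannot be ranked, so neither halogen shows any measurable gain over plain hydrogen here, and among the compounds shown only tert-butyl stands apart (a 6.0-fold higher number from compound 1 to compound 4 (0.78 log units; beyond the scatter)). Nothing available explains this pattern.

The compounds shown leave open whether the lower number belongs to tert-butyl alone or also appears with smaller carbon groups such as methyl or isopropyl. They also leave open how an amine or a carboxylic acid on this same aromatic carbon would compare with hydrogen.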